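Trifluoromethyl in Place of Allyloxy: an Expected Dose

A few compounds are considered here, and "the series" means these few. Any claim that something is new, unique, unknown or untested is made for them only; others in the source may bear on it.

Two measured compounds share one core and differ only in the group carried on one of the outer rings. Compound 1 `COc1ccccc1-c1n[nH]c(-c2ccccc2C)n1` carries a methoxy group, and in a functional assay on the whole organism (Cricetulus griseus) with Cricetinae gen. sp. as the target (on this read-out lower numbers stand for an effect already at smaller amounts and higher numbers for an effect only at larger amounts of compound), compound 1 gives 0.5 mg/kg. Compound 2 `C=CCOc1cccc(-c2nc(-c3ccccc3C)n[nH]2)c1` carries an allyloxy group instead, and in this assay compound 2 gives 0.15 mg/kg. This is the lowest of the two numbers; the nearest is compound 1, whose number is higher by a gap that lies beyond the usual scatter.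

Compound 3 `Cc1ccccc1-c1n[nH]c(-c2cccc(C(F)(F)F)c2)n1` is not yet measured. It differs from compound 2 by trifluoromethyl in place of allyloxy on an aromatic carbon. For the measured compounds named here, no step between measured compounds that differ in one place is available, so the size of this change has no direct precedent within the set. Since the allyloxy group of compound 2 goes with the lowest number seen, a move away from it is expected to shift the number upward by a modest amount, and the step is estimated at a 2.3-fold higher number from compound 2 to compound 3 (0.37 log units; beyond the scatter). Compound 3 is therefore expected to give 0.35 mg/kg in this assay, within a range from 0.1 mg/kg to 1.2 mg/kg.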

Compound 3, dose for half-maximal effect: 0.6 mg/kg
Estimate against measurement, compound 3: 1.7-fold (0.23 log units) below; the range from low to high includes it.
By their numbers in this assay, from the lowest: compound 2; then compounds 1 and 3 (each within the scatter of the next).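

In this assay, for the compounds shown here, trifluoromethyl in place of allyloxy on an aromatic carbon, meta to a large group, gives a 4.0-fold higher number from compound 2 to compound 3 (0.60 log units; beyond the scatter), the first step in the set that isolates a change at one place, and it shows that the read-out at this position depends on the group it carries. The two groups have the same number of heavy atoms, yet allyloxy, which has a double bond and a hydrogen-bond acceptor, goes with the lower number, while trifluoromethyl has neither feature; a single pair cannot show which difference, if any, accounts for the gap. No measurement available here explains the step, so its cause remains unassigned.

The compounds shown cannot separate the roles of the oxygen, the double bond and the length of the allyloxy chain, and a propoxy chain on this same carbon would bear directly on that question. As far as these compounds go, how an amine, a carboxylic acid or a longer ether chain on this carbon would read in this assay also remains open, as does whether this step would keep its size on another core.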